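The compounds below may be only part of what the source reports. "The series", "measured", "known", "first", "only" and "open" are said of these compounds alone.

Measured compounds: compound 1 `O=C(Oc1ccc2c(c1)CCC(=O)N2CCCN1CCN(c2ccccc2)CC1)c1ccccc1` with > 10000 nM in a functional assay on cell membranes for binding affinity to Sigma non-opioid intracellular receptor 1 (Rattus norvegicus) (on this read-out higher numbers stand for weaker inhibition and lower numbers for stronger inhibition), and compound 2 `COc1cccc2c1CCC(=O)N2CCCN1CCN(c2cccc(O)c2)CC1` with 810 nM in this assay.

For compound 1 the reported value is a limit of the assay and not a number, namely (the limit of > 10000 nM in this assay, at which 1 of the 2 values shown sits). For the measured compounds named here, compound 2 therefore stands alone as the only numerical value shown; the one further result is that limit. Going by the values given here, no step between two measured compounds is available, so no measured change can be set beside the new one.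

Compound 3 `COc1cccc2c1CCC(=O)N2CCCN1CCN(c2cccc(N)c2)CC1` differs from compound 2 by amino in place of hydroxy on an aromatic carbon. Among the compounds with values here, with no comparable measured step to lean on, the author expects a change from compound 2 to compound 3 of a 1.4-fold higher number from compound 2 to compound 3 (0.13 log units; within the scatter), that is, nothing clearly beyond the scatter in this assay, with a slight lean toward weaker inhibition. For compound 3 the estimated value in this assay is 1100 nM, within the range 300 nM to 4000 nM.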

Compound 3, half-maximal inhibitory concentration: 1210 nM
Compound 3: middle estimate off by 1.1-fold (0.04 log units), on the low side; the measured number falls inside the stated range.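

Going from 3-hydroxyphenyl to 3-aminophenyl gives a 1.5-fold higher number from compound 2 to compound 3 (0.17 log units; within the scatter) in this assay, so at this position the two groups cannot be told apart on this read-out. This is the only step shown between two measured compounds that differ in one place, and it shows that amino can take the place of hydroxy on this aromatic carbon, with the same count of hydrogen-bond donors and acceptors, without a change beyond the scatter. Nothing measured here bears on a reason for this outcome.

As far as these compounds go, it remains open whether a methoxy group, a fluorine atom or a carboxylic acid on the same aromatic carbon would read like hydroxy and amino. Also open, from the compounds shown here alone, is how a plain phenyl on the otherwise unchanged structure of compound 2 would compare.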